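Sulfur-linked side chain variation on the shared core

The source may hold more compounds than are shown below. What is called first, only, known or untested is meant among the compounds shown, and "the series" means these compounds.

Measured compounds:
compound 1 `CC(Sc1nc2c(cnn2C)c(=O)n1-c1ccccc1)c1ccccn1` — 89 nM
compound 2 `COc1cccc(C(C)Sc2nc3c(cnn3C)c(=O)n2-c2ccccc2)c1` — 174 nM

In an assay on isolated protein for inhibition of Retinaldehyde dehydrogenase 3 (Homo sapiens) (a higher number here means a weaker inhibitor, a lower number a stronger inhibitor), compound 1 gives the lower of the two numbers, with compound 2 nearest; the step of a 2.0-fold higher number from compound 1 to compound 2 (0.29 log units; within the scatter) is within the scatter. Compound 3 `C[C@H](Sc1nc2c(cnn2C)c(=O)n1-c1ccccc1)c1ccccc1` differs from compound 1 by 1-phenylethyl in place of 1-(pyridin-2-yl)ethyl on a sulfur. Within the data shown here, the only step bearing on this change is the one from compound 1 to compound 2, where the pyridin-2-yl ring was also replaced by a carbon-only ring, and it stayed within the scatter. A step of similar size, not beyond the scatter, is therefore expected in this assay, a 1.6-fold higher number from compound 1 to compound 3 (0.20 log units; within the scatter). Compound 3 is estimated at 140 nM, with a range of 60 nM to 350 nM.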

Compound 3, half-maximal inhibitory concentration: 1640 nM
Compound 3: middle estimate off by 12-fold (1.07 log units), on the low side; the whole stated range lies below it.
By their numbers in this assay, from the lowest: compounds 1 and 2 (each within the scatter of the next); then compound 3.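

In this assay, 1-phenylethyl in place of 1-(pyridin-2-yl)ethyl on a sulfur gives a large step (an 18-fold higher number from compound 1 to compound 3 (1.27 log units; beyond the scatter)), while the 3-methoxyphenyl change stayed within the scatter (a 2.0-fold higher number from compound 1 to compound 2 (0.29 log units; within the scatter)), so a carbon-only ring in place of pyridin-2-yl does not alone fix the outcome at this position. The entering group also carries a defined stereocentre, so ring change and stereochemistry cannot be separated in this step. Nothing available explains its size.

Open: how the mirror-image form of compound 3 reads, and how a pyridin-3-yl ring or a phenyl ring bearing an amine would read on the same chain carbon.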